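A few compounds are considered here, and "the series" means these few. Any claim that something is new, unique, unknown or untested is made for them only; others in the source may bear on it.

Measured so far:
- compound 1, `O/N=C(/Nc1cccc(F)c1)c1ccc2occc2c1`: 32700 nM
- compound 2, `O/N=C(/Nc1ccc(F)c(C(F)(F)F)c1)c1ccc2occc2c1`: 1200 nM

Both compounds were run in an assay on isolated protein for inhibition of Indoleamine 2,3-dioxygenase 1 (Homo sapiens), read by spectrophotometry; on this read-out lower numbers stand for stronger inhibition and higher numbers for weaker inhibition. Compound 1 holds the highest number of the two and so is the weaker of the pair; compound 2, which carries a trifluoromethyl group in addition to its fluoro substituent, sits far lower, and the gap between the two values lies well beyond the scatter of the assay. Two compounds with the same core are too few to call a trend.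

Compound 3, `CCCCOc1cccc(N/C(=N/O)c2ccc3occc3c2)c1`, has not yet been measured in this assay. It differs from compound 1 as follows: butoxy in place of fluoro on an aromatic carbon. Among the measured compounds shown here, nothing among the measured compounds tracks this change directly, so the size of the step rests on judgment alone. Given that compound 1 gives 32700 nM and that the butoxy group enters on the same six-membered ring that carried fluoro, a change from compound 1 to compound 3 of a 2.2-fold lower number from compound 1 to compound 3 (0.34 log units; beyond the scatter) toward a lower number is expected, a moderate step rather than a large one. The estimate for compound 3 in this assay is 15000 nM, with a range from 4000 nM to 60000 nM.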

Compound 3, half-maximal inhibitory concentration: > 30000 nM
Compound 3 ended at the assay's limit (the forecaster's own chance of this, stated with the estimate: 10%); middle value at least 2.0-fold (0.30 log units) away from the limit.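

In this assay compound 3 gives > 30000 nM, a limit of the assay and not a number. Among the compounds shown here, no step from compound 1 to compound 3 can be read for butoxy in place of fluoro. The compounds shown leave open whether this exchange raises, lowers or leaves unchanged the number seen for compound 1.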